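This account rests on a few compounds, and the source may have more. Where it says the series, first, only, none or still open, it means among the compounds named here.

In a functional assay on MCF7 cells (Homo sapiens) for cytotoxicity, read by MTT assay, with a stated time of 72 h (a lower number here means a stronger inhibitor, a higher number a weaker inhibitor), compound 1 `CCCCCCCCNc1nc(SCc2ccc(C(F)(F)F)cc2)nc2ccccc12` gives 26100 nM. Compound 2 `FC(F)(F)c1ccc(CSc2nc(N3CCCCC3)c3ccccc3n2)cc1` reaches only the limit of this assay at > 50000 nM, which is a limit and not a number. Compound 2 thus stands at the weaker end of the two values shown, as the limit of > 50000 nM in this assay, at which 1 of the 2 values shown sits, records. For the measured compounds named here, the only measured step is an at least 1.9-fold higher number from compound 1 to compound 2 (0.28 log units; that floor lies within the scatter), and its floor lies within the scatter, so the data leave open whether that change mattered at all.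

Compound 3 `FC(F)(F)c1ccc(CSc2nc(Nc3ccccc3C(F)(F)F)c3ccccc3n2)cc1` differs from compound 2 by (2-(trifluoromethyl)phenyl)amino in place of piperidin-1-yl on an aromatic carbon. Going by the values given here, no measured step carries this change, and the starting point of compound 2 is a limit rather than a number, so the size of the step in this assay can only be guessed. The entering group brings 1 hydrogen-bond donor, which the octylamino of compound 1 also carries, and that is the sole thread the shown compounds offer. Compound 3 is therefore expected to give 30000 nM, within a range from 10000 nM to 80000 nM. The expected step is an at least 1.6-fold lower number from compound 2 to compound 3 (0.22 log units; that floor lies within the scatter), a change that may not exceed the scatter.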

Compound 3, half-maximal inhibitory concentration: > 50000 nM
Compound 3 gave a limit, no number; the forecaster's own chance of this, stated with the estimate: 35%; middle value at least 1.6-fold (0.22 log units) away from the limit.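

Compound 3 shows that, in this assay, a hydrogen-bond donor on the aromatic carbon next to the ring nitrogen does not by itself give a readable number, since compound 3 carries one, as compound 1 does, and still yields only a limit. Compound 2 and compound 3 thus rest at the same limit, which is no number, so the step between them cannot be read, and neither the saturated piperidin-1-yl nor the aromatic (2-(trifluoromethyl)phenyl)amino can be ranked against the other: the limit of > 50000 nM in this assay, at which 2 of the 3 values shown sit. With the nitrogen kept in place, 2-(trifluoromethyl)phenyl in place of octyl gives an at least 1.9-fold higher number from compound 1 to compound 3 (0.28 log units; that floor lies within the scatter), so this comparison, like the one with piperidin-1-yl, does not establish that the octyl chain matters.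

Whether any group at this position gives a number clearly apart from the limit remains open, and compound 1 is the only compound shown with a number to start from. A longer chain such as dodecylamino, or a shorter one such as butylamino, would test whether the length of the chain on this nitrogen has any bearing on the value in this assay.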